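The compounds below may be only part of what the source reports. "The series", "measured", "known", "first", "only" and "open" are said of these compounds alone.

Adding a second methyl to the naphthyl-free question? No: 

Sorry, that opening line was a false start; the notes follow.

One more methyl on the series core

Growth inhibition in a functional assay on U-251 cells (Homo sapiens) for antiproliferative activity; a higher number here means a weaker inhibitor of growth, a lower number a stronger inhibitor of growth:
- compound 1 `Oc1cc(-c2ccc3ccccc3c2)nc2ncccc12`: 4370 nM
- compound 2 `Cc1cc(C)c2c(O)cc(-c3cccc(Cl)c3)nc2n1`: 295 nM
- compound 3 `Cc1ccnc2nc(-c3ccc4ccccc4c3)cc(O)c12`: 646 nM

Compound 3 holds the second highest of the three numbers, with compound 2 lower and compound 1 higher, both gaps beyond the scatter. Compound 4 `Cc1cc(C)c2c(O)cc(-c3ccc4ccccc4c3)nc2n1` differs from compound 3 by methyl in place of hydrogen on an aromatic carbon, next to the ring nitrogen. Among the measured compounds shown here, the only measured step of this kind is a 6.8-fold lower number from compound 1 to compound 3 (0.83 log units; beyond the scatter), and it lies at another carbon, so it is a loose guide. Compound 4 shares its methyl groups with compound 2, which gives 295 nM with a different aromatic group. A lower number is therefore expected in this assay, smaller in size than the measured step, and the estimated step is a 2.2-fold lower number from compound 3 to compound 4 (0.33 log units; beyond the scatter). For compound 4 the estimated value is 300 nM, with an expected range of 110 nM to 800 nM.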

Compound 4, concentration for 50% growth inhibition: 15800 nM
Estimate against measurement, compound 4: 53-fold (1.72 log units) below; the whole stated range lies below it.
By their numbers in this assay, from the lowest: compound 2; then compound 3; then compound 1; then compound 4.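

In this assay, methyl in place of hydrogen on the aromatic carbon next to the ring nitrogen gives a 24-fold higher number from compound 3 to compound 4 (1.39 log units; beyond the scatter) and runs against the earlier step at another carbon, a 6.8-fold lower number from compound 1 to compound 3 (0.83 log units; beyond the scatter) and so the effect of this change depends on which carbon carries the methyl. The methyl pair does not rule out a low number, since compound 2, which has the same methyl groups with a different aromatic group, gives 295 nM in this assay while the loss appears with the naphthyl-bearing compound 4. Nothing available accounts for this reversal.

Going by these compounds, whether a fluorine, a methoxy group or an amine at this carbon would behave as methyl does remains open. Also open, on these data alone, is whether the chlorophenyl series would show the same loss on gaining this methyl.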